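The compounds below may be only part of what the source reports. "The series", "measured", "known", "first", "only" and "open" are said of these compounds alone.

The three measured compounds are:

Compound 1, `Cc1nc(NC(=O)c2ccccc2)sc1C(=O)/C=C/c1ccc(F)cc1`, gives 98%.
Compound 2, `COc1ccc(/C=C/C(=O)c2sc(NC(=O)c3ccccc3)nc2C)cc1`, gives 58.8%.
Compound 3, `Cc1ccc(/C=C/C(=O)c2sc(NC(=O)c3ccc(F)cc3)nc2C)cc1`, gives 91.5%.

All three numbers come from an assay for inhibition of Polyunsaturated fatty acid 5-lipoxygenase (Homo sapiens), read by spectrophotometry, tested at 10 uM, in the presence of a further agent that is not named here; a higher number here means more inhibition at the concentration tested (going by the name of the read-out), a lower number less inhibition. Compound 1 and compound 2 share a core and differ in one place only: methoxy in place of fluoro on an aromatic carbon. That single change made a large step, a number 39.2 percentage points lower from compound 1 to compound 2 (beyond the scatter), well beyond the usual scatter of such measurements. Compound 3 carries a different core; how its core differs from that of compound 1 is not broken down here. In this assay compound 3 and compound 1 give numbers that lie within the scatter of each other, so nothing can be said about which of the two inhibits more; compound 2 lies clearly lower than both.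

The unmeasured compound 4, `COc1ccc(C(=O)Nc2nc(C)c(C(=O)/C=C/c3ccc(C)cc3)s2)cc1`, stands to compound 3 as compound 2 stands to compound 1: methoxy in place of fluoro on an aromatic carbon. The place of the change is described in the same words for both pairs, so this is the same change, made on another core. Among the compounds with values here, the only evidence on its effect is the one step seen from compound 1 to compound 2. Resting on that, a drop of similar size is expected from compound 3 to compound 4, namely a number 36.5 percentage points lower from compound 3 to compound 4 (beyond the scatter), although a change can act differently on a different core, which widens the uncertainty. Compound 4 is therefore estimated to give about 55% in this assay, most likely between 35% and 78%.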

Compound 4, a percentage reported as inhibition, at one concentration (the size of the read-out at that concentration, not a potency): 100%
Compound 4: the middle estimate sits 45 percentage points below what was measured; the measured number lies above the stated range.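

In this assay, exchanging 4-fluorophenyl for 4-methoxyphenyl on the second core gave a number 8.5 percentage points higher from compound 3 to compound 4 (within the scatter), so the large drop seen on the first core did not reappear here. The two outcomes of one and the same change differ by more than repeat measurements would normally explain: the same change on two cores in this assay, a number 39.2 percentage points lower (beyond the scatter) from compound 1 to compound 2 and a number 8.5 percentage points higher (within the scatter) from compound 3 to compound 4, 47.7 percentage points apart, beyond the scatter of two such steps. This shows that, in this series, the effect of the change on one core cannot safely be carried over to another, but two pairs cannot show which structural difference between the cores decides the outcome, nor what the change would do on any further core.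

The compounds shown leave open how other groups would behave in the place of the fluoro and methoxy groups, for example an amine, a carboxylic acid or a longer chain such as butoxy, and whether any such group would again depend on the core that carries it. Also open, as far as these compounds go, is whether the same picture would hold in a full potency measurement, since every number here comes from a single tested concentration and says nothing directly about the concentration needed for a given level of inhibition.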